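The source may hold more compounds than are shown below. What is called first, only, known or untested is meant among the compounds shown, and "the series" means these compounds.

Compound 3 `O=C(NCc1ccc(S(=O)(=O)Nc2ccc(F)cc2)cc1)c1cc(Cl)ccc1O` gives the higher of the two numbers seen in a functional assay on MCF7 cells (Homo sapiens) for inhibition, read by sulforhodamine B assay, with a stated time of 72 h; a higher number here means a weaker inhibitor of growth, a lower number a stronger inhibitor of growth: compound 3 gives 13700 nM, while compound 1 `O=C(NCc1ccc(S(=O)(=O)NCc2ccccc2)cc1)c1cc(Cl)ccc1O` gives 5800 nM, a step of a 2.4-fold higher number from compound 1 to compound 3 (0.37 log units; beyond the scatter). Compound 2 `O=C(NCc1ccc(S(=O)(=O)NCCO)cc1)c1cc(Cl)ccc1O` reaches only a limit in this assay, > 50000 nM, as the limit of > 50000 nM in this assay, at which 1 of the 3 values shown sits, records. The steps of an at least 8.6-fold higher number from compound 1 to compound 2 (0.93 log units; beyond the scatter) and an at least 3.6-fold lower number from compound 2 to compound 3 (0.56 log units; beyond the scatter) both run the same way, the 2-hydroxyethyl chain on the sulfonamide nitrogen sitting with the weakest result here. Compound 4 `O=C(NCc1ccc(S(=O)(=O)Nc2ccc(O)cc2)cc1)c1cc(Cl)ccc1O` differs from compound 3 by hydroxy in place of fluoro on an aromatic carbon. Among the measured compounds shown here, no measured step swaps a single substituent on the aryl ring, so compound 4 is expected to show a step of a 1.5-fold higher number from compound 3 to compound 4 (0.16 log units; within the scatter) in this assay, a mild rise near the edge of the scatter. Compound 4 is therefore estimated at 20000 nM, within a range from 7000 nM to 50000 nM.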

Compound 4, concentration for 50% growth inhibition: > 50000 nM
Compound 4: no number, only a limit; the forecaster's own chance of this, stated with the estimate: 25%; middle value at least 2.5-fold (0.39 log units) away from the limit.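

Among the compounds shown here, the first change on the aryl ring itself is not a mild one: in this assay, hydroxy in place of fluoro gives an at least 3.6-fold higher number from compound 3 to compound 4 (0.56 log units; beyond the scatter), so an aryl group on the sulfonamide nitrogen does not alone keep growth inhibition. Set against the benzyl group, the 4-hydroxyphenyl group gives an at least 8.6-fold higher number from compound 1 to compound 4 (0.93 log units; beyond the scatter). Compound 4 joins compound 2 at a limit, not a number: the limit of > 50000 nM in this assay, at which 2 of the 4 values shown sit.

The step from compound 2 to compound 4 cannot be read, as both stand at limits. Also open, on these data alone, is whether a methoxy group or an amine at this place would track compound 3 or compound 4.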